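Moving the chlorines on the phenoxy ring of compound 2

The source may hold more compounds than are shown below. What is called first, only, known or untested is meant among the compounds shown, and "the series" means these compounds.

Compound 2 `O=C(COc1ccc(Cl)cc1Cl)NNC(=S)NCc1ccc(-c2ccccc2)cc1` holds the lower of the two numbers measured in an assay on isolated protein for inhibition of A disintegrin and metalloproteinase with thrombospondin motifs 5 (Homo sapiens), read by spectrophotometry, with stated times of 10 min and 3 h (a higher number here means a weaker inhibitor, a lower number a stronger inhibitor), giving 1200 nM, while compound 1 `O=C(COc1ccccc1)NNC(=S)NCc1ccc(-c2ccccc2)cc1` gives 10000 nM. For the measured compounds named here, the one measured step, an 8.3-fold lower number from compound 1 to compound 2 (0.92 log units; beyond the scatter), shows that adding two chlorines to the phenoxy ring matters. Going by the values given here, compound 3 `O=C(COc1ccc(Cl)c(Cl)c1)NNC(=S)NCc1ccc(-c2ccccc2)cc1` differs from compound 2 by 3,4-dichlorophenyl in place of 2,4-dichlorophenyl on an oxygen on a saturated carbon; no measured step speaks to moving a chlorine within the ring, so no step beyond the scatter is expected, no change at the digits printed from compound 2 to compound 3 (within the scatter). Compound 3 is therefore estimated at 1200 nM, expected between 400 nM and 4000 nM in this assay.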

Compound 3, half-maximal inhibitory concentration: 1200 nM
Estimate against measurement, compound 3: no gap at the digits printed, within the range that was stated.
By their numbers in this assay, from the lowest: compounds 2 and 3 (each within the scatter of the next); then compound 1.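

In this assay the 3,4-dichlorophenyl and 2,4-dichlorophenyl groups on this oxygen cannot be told apart, with no change at the digits printed from compound 2 to compound 3 (within the scatter) for the exchange. Measured against plain phenyl, the new pattern gives an 8.3-fold lower number from compound 1 to compound 3 (0.92 log units; beyond the scatter) as its step, so the lower number seen earlier is not confined to the 2,4-dichlorophenyl arrangement. No evidence bears on why the two arrangements read alike.

On these data alone, whether a single chlorine would carry the same step remains open, and so does whether a methoxy group or a carboxylic acid on this ring would hold the number.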